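The compounds below may be only part of what the source reports. "The series", "measured", "known", "first", "only" and "open" are said of these compounds alone.

Compound 1, with the structure `c1ccc(/N=c2\ssnc2-c2ccccc2)cc1`, was tested in a functional assay on MCF7 cells (Homo sapiens) for antiproliferative activity, read by MTT assay, with a stated time of 72 h (a lower number here means a stronger inhibitor of growth, a higher number a weaker inhibitor of growth), where compound 1 gives 10000 nM. Compound 2, `O=[N+]([O-])c1ccc(-c2nss/c2=N\c2ccccc2)cc1`, carries a nitro in place of hydrogen on an aromatic carbon, described by nitro in place of hydrogen on an aromatic carbon. In this assay compound 2 gives 10000 nM, so the step of no change at the digits printed from compound 1 to compound 2 (within the scatter) amounts to no change within the scatter of this kind of measurement.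

Compound 3 has the structure `S=c1ssnc1-c1ccccc1`. It rests on a different core from compound 1, and the difference between the two cores is not broken down here. In this assay compound 3 gives only a limit, > 10000 nM, meaning the assay reports no number for it; this is the limit noted as the limit of > 10000 nM in this assay, at which 1 of the 3 values shown sits, where one of the three values sits.

Compound 4, `O=[N+]([O-])c1ccc(-c2nssc2=S)cc1`, has not yet been measured. It differs from compound 3 by the change (nitro in place of hydrogen on an aromatic carbon). For the measured compounds named here, this is the same kind of change as the one from compound 1 to compound 2, though not the same: around the place, the surroundings are worded as para to a group of 6 heavy atoms in one case and para to a large group in the other.

Because the step of no change at the digits printed from compound 1 to compound 2 (within the scatter) brought no change, the step from compound 3 to compound 4 is expected to be a step that the limit leaves unreadable from compound 3 to compound 4, a similarly flat one, and a limit rather than a number would not be surprising. Compound 4 is therefore estimated at 15000 nM, with a likely range from 7000 nM to 50000 nM.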

Compound 4, concentration for 50% growth inhibition: > 10000 nM
Compound 4: a limit, no number; the forecaster's own chance of this, stated with the estimate: 70%; the middle value does not contradict the limit.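

In this assay, no step can be read from compound 3 to compound 4, because both compounds give only a limit of the assay and no number: the limit of > 10000 nM in this assay, at which 2 of the 4 values shown sit.

The compounds shown leave open what number either compound would give, and whether nitro in place of hydrogen on an aromatic carbon changes growth inhibition at all on the core of compound 3.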